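Removing the bromine from an inactive triazole pair

The source may hold more compounds than are shown below. What is called first, only, known or untested is meant among the compounds shown, and "the series" means these compounds.

Compound 1 `C=C1C[C@]23C[C@@]1(O)CC[C@H]2c1ccc(O)c(C)c1[C@@H]3Cn1cc(-c2ccccn2)nn1`: > 20000 nM
Compound 2 `C=C1C[C@]23C[C@@]1(O)CC[C@H]2c1ccc(O)c(C)c1[C@@H]3Cn1cc(-c2ccc(Br)cc2)nn1`: > 20000 nM

Of the compounds shown here, two have been measured so far in a functional assay on HL-60 cells (Homo sapiens) for cytotoxicity, read by MTT assay, with a stated time of 4 days; a lower number here means a stronger inhibitor, a higher number a weaker inhibitor. Compound 1 gives > 20000 nM, which is a limit of this assay rather than a measured number. Compound 2 gives > 20000 nM, again a limit and not a number. Among the compounds with values here, with both ends hidden, the step that the two limits leave unreadable from compound 1 to compound 2 cannot be read, and compound 2 stands nowhere in particular: it simply sits at the limit of > 20000 nM in this assay, at which 2 of the 2 values shown sit, together with the only other value shown.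

The next compound, compound 3 `C=C1C[C@]23C[C@@]1(O)CC[C@H]2c1ccc(O)c(C)c1[C@@H]3Cn1cc(-c2ccccc2)nn1`, differs from compound 2 by hydrogen in place of bromo on an aromatic carbon. Within the data shown here, no measured step bears on this change with a readable size, since the one step available is unreadable. Nothing shown therefore points to a move beyond the scatter in either direction. Compound 3 is accordingly expected to remain where compound 2 is, at about 30000 nM, with an estimated range from 12000 nM to 100000 nM, most probably reported once more only as a limit. The step expected from this is a step that the limit leaves unreadable from compound 2 to compound 3, that is, no change beyond the scatter.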

Compound 3, half-maximal inhibitory concentration: > 20000 nM
Compound 3 gave a limit, no number (the forecaster's own chance of this, stated with the estimate: 85%); the middle value does not contradict the limit.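

Compound 3 also gives a limit rather than a number, so no step among compound 1, compound 2 and compound 3 can be read in this assay: the limit of > 20000 nM in this assay, at which 3 of the 3 values shown sit.

The compounds shown leave open how far apart these three really lie, and whether any change to the shared core would give a readable value.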